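This account rests on a few compounds, and the source may have more. Where it says the series, first, only, none or still open, it means among the compounds named here.

Three compounds have numbers in a functional assay on cells (T-cell, Homo sapiens) for cytotoxicity; on this read-out lower numbers stand for stronger inhibition and higher numbers for weaker inhibition. In that assay, compound 1 (`C/C(=N\Nc1ccc([N+](=O)[O-])cc1)c1ccc(O)cc1`) gives 4.1 ug/mL, compound 2 (`O=[N+]([O-])c1cc([N+](=O)[O-])c(NN=C(c2ccc(O)cc2)c2ccc(O)cc2)cc1Cl`) gives 1.5 ug/mL and compound 3 (`O=[N+]([O-])c1ccccc1NN=C(c1ccc(O)cc1)c1ccc(O)cc1`) gives 2.7 ug/mL. Compound 3 holds the second highest of the three numbers, but its distances to compound 1 and to compound 2 both lie within the usual scatter of repeated measurements.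

Compound 4 (`O=[N+]([O-])c1ccc(NN=C(c2ccc(O)cc2)c2ccc(O)cc2)c([N+](=O)[O-])c1`) has not yet been measured. It differs from compound 3 by a single change, nitro in place of hydrogen on an aromatic carbon, meta to a nitro group and para to a large group.

Among the compounds with values here, no two measured compounds differ in one place only, so the data do not isolate this change. The closest guide is compound 2, which also carries a second nitro group, together with other differences, and gives 1.5 ug/mL. On that limited evidence, a small move toward a lower number is expected in this assay, one that probably stays within the scatter. The expected size of this move is a 1.4-fold lower number from compound 3 to compound 4 (0.13 log units; within the scatter). For compound 4 the estimated value is 2 ug/mL, with an expected range from 0.9 ug/mL to 4.5 ug/mL.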

Compound 4, half-maximal inhibitory concentration: 3.2 ug/mL
Compound 4: the middle estimate sits 1.6-fold (0.20 log units) below what was measured, and the stated range covers the measured number.
By their numbers in this assay, from the lowest: compounds 2, 3, 4 and 1 (each within the scatter of the next, the first and the last beyond it).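

In this assay, the nitro in place of hydrogen on an aromatic carbon, meta to a nitro group and para to a large group, gives a 1.2-fold higher number from compound 3 to compound 4 (0.07 log units; within the scatter), so this position takes a second nitro group with no change that can be told from the scatter. The chloro group gives the other one-place comparison: hydrogen in place of chloro on an aromatic carbon gives a 2.1-fold higher number from compound 2 to compound 4 (0.33 log units; beyond the scatter), a modest step and the only one of the two that lies beyond the scatter. Nothing measured here bears on why either step has the size it has.

The compounds shown leave open whether an amine or a carboxylic acid in place of the added nitro group would stay as close to compound 3, and whether bromo or methoxy in place of the chloro group would match the number of compound 2 or that of compound 4. They also leave open whether the same nitro change would read the same way on the core of compound 1.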